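A few compounds are considered here, and "the series" means these few. Any claim that something is new, unique, unknown or untested is made for them only; others in the source may bear on it.

Measured so far:
compound 1 `NC(=S)Nc1cccc(OCCCCCN2CCN(c3ccc(C4CCCCC4)cc3)C2=S)c1`, reported only as an assay limit, > 50000 nM
compound 2 `NC(=S)Nc1cccc(OCCCCCNC(=S)Nc2cc(Cl)cc(Cl)c2)c1`, 18000 nM
compound 3 `NC(=S)Nc1cccc(OCCCCCCCCNC(=S)Nc2cc(Cl)cc(Cl)c2)c1`, 12000 nM

All three share the same core and were tested in an ADME assay on Huh-7 cells (Homo sapiens) for cytotoxicity; a lower number here means that less compound is tolerated, a higher number that more compound is tolerated. Compound 3 and compound 2 give numbers that lie within the usual scatter of each other, so neither can be called better tolerated than the other. Compound 1 sits apart in that its value is not a number but a limit, (the limit of > 50000 nM in this assay, at which 1 of the 3 values shown sits).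

Compound 4 `NC(=S)Nc1cccc(OCCCCCCCCNC(=S)Nc2cccc(Br)c2)c1` has not yet been measured. It differs from compound 3 in one place: 3-bromophenyl in place of 3,5-dichlorophenyl on an amide-type nitrogen. Going by the values given here, no measured pair shows the effect of such a change, so the expectation rests on compound 3 alone. Among the compounds with values here, with no step of this kind on record, the expected step from compound 3 to compound 4 in this assay is no change at the digits printed from compound 3 to compound 4 (within the scatter), that is, nothing beyond the scatter. Compound 4 is therefore estimated at 12000 nM, with a likely range from 5000 nM to 35000 nM.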

Compound 4, half-maximal cytotoxic concentration: 20000 nM
Compound 4: the middle estimate sits 1.7-fold (0.22 log units) below what was measured; the measured number falls inside the stated range.
By their numbers in this assay, from the lowest: compounds 3, 2 and 4 (each within the scatter of the next). At a limit, above all of these: compound 1.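

In this assay, 3-bromophenyl in place of 3,5-dichlorophenyl on an amide-type nitrogen gives a 1.7-fold higher number from compound 3 to compound 4 (0.22 log units; within the scatter). Going by these compounds alone, this is the first measured change at this position, and it shows that replacing two chlorine atoms with one bromine atom on the phenyl ring does not separate the two compounds in this read-out, so neither can be called better tolerated. Nothing measured here explains the size of this step.

From the compounds shown here alone, what a plain phenyl, or a phenyl carrying a carboxylic acid or an amine, would give at this nitrogen remains open. Going by these compounds, it is also open whether the same exchange would give a step of similar size on the chain of compound 2, since a single pair cannot show whether the result holds on another chain.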